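The source may hold more compounds than are shown below. What is called first, only, known or untested is meant among the compounds shown, and "the series" means these compounds.

Among the measured compounds shown here, compound 1, `COc1cc(/C=C/C(=O)c2cccc(NC(=O)c3cc(Cl)cc(Cl)c3)c2)ccc1O`, gives the highest of the three numbers so far in a functional assay on SiHa cells (Homo sapiens) for inhibition (on this read-out higher numbers stand for weaker inhibition and lower numbers for stronger inhibition), namely 17.7 ug/mL. Its nearest neighbour is compound 3, `COc1cc(/C=C/C(=O)c2cccc(N)c2)ccc1O`, which gives 12.3 ug/mL, a difference that stays within the scatter; the step is a 1.4-fold lower number from compound 1 to compound 3 (0.16 log units; within the scatter). Far from both stands compound 2, `COc1cc(/C=C/C(=O)c2cccc(NC(=O)c3ccco3)c2)ccc1O`, which gives 0.76 ug/mL; the step is a 23-fold lower number from compound 1 to compound 2 (1.37 log units; beyond the scatter), and from compound 2 to compound 3 it reads a 16-fold higher number from compound 2 to compound 3 (1.21 log units; beyond the scatter).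

Compound 4, `COc1cc(/C=C/C(=O)c2cccc(NC(C)=O)c2)ccc1O`, differs from compound 1 in one place: methyl in place of 3,5-dichlorophenyl on a carbonyl carbon. Both measured steps bear on it, since each also alters what sits on the carbonyl carbon or removes that carbonyl altogether. The furan-2-yl exchange brought a large drop in the number, while removal of the whole (3,5-dichlorophenyl)carbonyl left the number essentially unchanged. A methyl on the carbonyl carbon sits between these cases, so a moderate step toward a lower number is expected, with wide uncertainty: a 2.5-fold lower number from compound 1 to compound 4 (0.40 log units; beyond the scatter). For compound 4 the expected value in this assay is 7 ug/mL, within a range from 1.5 ug/mL to 30 ug/mL.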

Compound 4, half-maximal inhibitory concentration: 15.8 ug/mL
Beside the measured number, compound 4's estimate is 2.3-fold (0.35 log units) below it; the measured number falls inside the stated range.
By their numbers in this assay, from the lowest: compound 2; then compounds 3, 4 and 1 (each within the scatter of the next).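

In this assay, acetyl on the nitrogen leaves the number where the bare amine has it (a 1.3-fold higher number from compound 3 to compound 4 (0.11 log units; within the scatter)), and methyl on the carbonyl carbon reads the same as 3,5-dichlorophenyl (a 1.1-fold lower number from compound 1 to compound 4 (0.05 log units; within the scatter)). Among these compounds, acylation of the nitrogen as such therefore does not move the number, and the furan-2-yl compound alone stands apart, now also from the acetyl compound (a 21-fold higher number from compound 2 to compound 4 (1.32 log units; beyond the scatter)). Nothing measured here accounts for that separation.

From the compounds shown here alone, whether the low number is particular to furan-2-yl stays open, and an unsubstituted phenyl or a thienyl group on the same carbonyl carbon would bear on this. Also open, going by these compounds, is whether a longer chain, such as butyl in place of methyl, would read like acetyl or move toward the furan-2-yl compound.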